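The source may report more compounds than this note shows. Statements on the series, on what has been measured and on what is new or still open speak of the compounds shown alone.

Compound 1, whose structure is `Cc1cc(NC(=O)Nc2cccc(C(N)=O)c2)c2ccccc2n1`, was tested in an ADME assay on HepG2 cells (Homo sapiens) for cytotoxicity, with a stated time of 72 h; on this read-out lower numbers stand for an effect already at smaller amounts and higher numbers for an effect only at larger amounts of compound. In this assay compound 1 gives > 25000 nM, which is a limit of the assay rather than a number. A second compound, compound 2 with the structure `CSc1ccccc1NC(=O)Nc1cc(C)nc2ccccc12`, was tested in this assay as well. In this assay compound 2 gives > 25000 nM, again a limit and not a number. Compound 1 therefore stands at the limit of > 25000 nM in this assay, at which 2 of the 2 values shown sit, so nothing separates the two measured compounds in this assay. The unmeasured compound 3 has the structure `Cc1cc(NC(=O)Nc2cccc([N+](=O)[O-])c2)c2ccccc2n1`. It differs from compound 1 by nitro in place of carbamoyl on an aromatic carbon. For the measured compounds named here, no step between measured compounds is known here, so the expectation for this change can rest only on compound 1 sitting at the limit of > 25000 nM in this assay, at which 2 of the 2 values shown sit; the step from compound 1 to compound 3 is expected to be none beyond the scatter. Compound 3 is thus estimated at 25000 nM, within a range of 8000 nM to 60000 nM, with the expected step being a number no higher from compound 1 to compound 3 (the limit leaves the size open).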

Compound 3, half-maximal effective concentration: > 25000 nM
Compound 3: a limit, no number; the forecaster's own chance of this, stated with the estimate: 80%; the middle value lies on the limit itself.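

For the compounds shown here, compound 1 and compound 3 both give only a limit in this assay, so no step between them can be read: the limit of > 25000 nM in this assay, at which 3 of the 3 values shown sit. The compounds shown leave open what number any of them would give, and whether nitro in place of carbamoyl changes that number at all.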